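The source may hold more compounds than are shown below. What is called first, only, known or untested is meant among the compounds shown, and "the series" means these compounds.

Of the compounds shown here, three have been measured in an assay on HEK293 cells for inhibition of N-acylethanolamine-hydrolyzing acid amidase (Rattus norvegicus), read by LC-MS, with a stated time of 30 min; a lower number here means a stronger inhibitor, a higher number a weaker inhibitor. Compound 1, with structure `O=C(CCCCCCc1ccccc1)N1CCCC1`, gives 12900 nM. Compound 3, with structure `O=C(CCCCCCc1ccc(O)cc1)N1CCCC1`, gives 5600 nM. Compound 2, with structure `O=C(CCc1ccc(-c2ccccc2F)cc1)N1CCCC1`, gives 2800 nM. Compound 2 thus shows the lowest of the three numbers, though its gap to compound 3 lies within the usual scatter, so the two cannot be ranked; only compound 1 stands clearly apart from it.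

Among the measured compounds shown here, the single step between measured compounds that differ in one place is a 2.3-fold lower number from compound 1 to compound 3 (0.36 log units; beyond the scatter), a modest change produced by placing a hydroxy group on the aromatic ring of compound 1. That step concerns a different change and a different part of the molecule than the one considered here, so it offers only a loose guide.

Compound 4, with structure `O=C(CCc1ccc(-c2ccccn2)cc1)N1CCCC1`, differs from compound 2 by pyridin-2-yl in place of 2-fluorophenyl on an aromatic carbon. For the measured compounds named here, no measured step touches this kind of replacement. Going by the values given here, the only comparable change in this small set, the step from compound 1 to compound 3, was modest, so an expected step beyond the scatter has no footing in the data. For compound 4, the number in this assay is expected to stay close to that of compound 2, with a 1.3-fold higher number from compound 2 to compound 4 (0.10 log units; within the scatter) as the estimated step. Compound 4 is therefore estimated at 3500 nM, with a range from 1200 nM to 10000 nM.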

Compound 4, half-maximal inhibitory concentration: > 100000 nM
Compound 4: only a limit was reported; the forecaster's own chance of this, stated with the estimate: 5%; middle value at least 28-fold (1.45 log units) away from the limit.
By their numbers in this assay, from the lowest: compounds 2 and 3 (each within the scatter of the next); then compound 1. At a limit, above all of these: compound 4.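

Among the compounds shown here, putting pyridin-2-yl in place of 2-fluorophenyl on this aromatic carbon, para to a group of 9 heavy atoms, gives an at least 35-fold higher number from compound 2 to compound 4 (1.55 log units; beyond the scatter) in this assay, whereas the only earlier step, a 2.3-fold lower number from compound 1 to compound 3 (0.36 log units; beyond the scatter), was modest and concerned a different change. The new step shows that activity at this position can depend strongly on which six-membered aromatic ring is attached, even though the two groups are alike in being single rings with no net charge and differ in the ring nitrogen, the hydrogen-bond acceptor it adds, and the fluorine that leaves. The value of compound 4 is a limit rather than a number, so the step has a minimum size but no known full size, and compound 4 alone stands at that limit: the limit of > 100000 nM in this assay, at which 1 of the 4 values shown sits.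

The swap changes two things at once, so the loss of the fluorine and the gain of the ring nitrogen cannot be separated here. As far as these compounds go, an unsubstituted phenyl group or a fluorine-bearing pyridine ring at this position would help to show which of the two matters, and that question stays open.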